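Replacing 4-(trifluoromethyl)phenyl with 2,4-dimethylphenyl on a carbonyl carbon

The source may report more compounds than this note shows. Statements on the series, on what has been measured and on what is new or still open speak of the compounds shown alone.

Of the compounds shown here, two on the shared core have been measured so far. In a functional assay on HepG2 cells (Homo sapiens) for antiproliferative activity, read by MTT assay, with a stated time of 48 h (on this read-out lower numbers stand for stronger inhibition and higher numbers for weaker inhibition), compound 1 `COc1ccc(/C=C/c2cc(OC)cc(OC)c2/C=C/C(=O)c2ccc(Br)cc2)cc1` gives 12.9 ug/mL. Compound 2 `COc1ccc(/C=C/c2cc(OC)cc(OC)c2/C=C/C(=O)c2ccc(C(F)(F)F)cc2)cc1` gives 18.7 ug/mL, which places it level with compound 1 within the scatter.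

The next compound is compound 3 `COc1ccc(/C=C/c2cc(OC)cc(OC)c2/C=C/C(=O)c2ccc(C)cc2C)cc1`, which carries 2,4-dimethylphenyl in place of 4-(trifluoromethyl)phenyl on a carbonyl carbon. Among the compounds with values here, no measured compound carries the 2,4-dimethylphenyl group, so there is no direct precedent for it.

Within the data shown here, the only measured step that bears on the change is a 1.4-fold higher number from compound 1 to compound 2 (0.16 log units; within the scatter), with trifluoromethyl in place of bromo on an aromatic carbon. That single step is a thin basis, and it gives no sign of a large response to exchanging groups at this end of the molecule. The expectation is therefore anchored on compound 2 at 18.7 ug/mL.

The step expected in this assay is a 1.2-fold lower number from compound 2 to compound 3 (0.10 log units; within the scatter), so no move beyond the scatter is anticipated. For compound 3 the estimated value is 15 ug/mL, with an expected range of 6 ug/mL to 38 ug/mL.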

Compound 3, half-maximal inhibitory concentration: 0.9 ug/mL
The estimate for compound 3 lay 17-fold (1.22 log units) above the measured number; measured number below the stated range.
By their numbers in this assay, from the lowest: compound 3; then compounds 1 and 2 (each within the scatter of the next).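

In this assay, the group on the carbonyl carbon turns out to be a position that responds strongly to exchange: 2,4-dimethylphenyl gives a 21-fold lower number from compound 2 to compound 3 (1.32 log units; beyond the scatter) and a 14-fold lower number from compound 1 to compound 3 (1.16 log units; beyond the scatter). The earlier exchange of bromo for trifluoromethyl, a 1.4-fold higher number from compound 1 to compound 2 (0.16 log units; within the scatter), showed no such response, so compounds 1 and 2 stay level while compound 3 stands apart from both, beyond the scatter, as the strongest of the three on this read-out. Nothing at hand offers an explanation for the size of this gain.

The series shown leaves open whether one of the two methyl groups of 2,4-dimethylphenyl accounts for the gain or whether both are needed, since they enter together in a single change and also replace a different substituent on the ring. Also open, as far as these compounds go, is how far the response extends to other groups on this carbonyl carbon, such as a phenyl ring carrying an amine or a carboxylic acid, and whether the gain on this core persists outside this assay.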